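A Carbamoylpiperidine Replaces the Cyclohexylamine

This account rests on a few compounds, and the source may have more. Where it says the series, first, only, none or still open, it means among the compounds named here.

Of the compounds shown here, two built on the same core have been tested in a functional assay on PC-3 cells (Homo sapiens) for cytotoxicity, read by MTT assay, with a stated time of 48 h; on this read-out higher numbers stand for weaker inhibition and lower numbers for stronger inhibition. Compound 1 `CCCNCC(=O)N1N=C(c2cc3ccccc3oc2=O)CC1c1ccccc1` gives 7270 nM. Compound 2 `O=C(CNC1CCCCC1)N1N=C(c2cc3ccccc3oc2=O)CC1c1ccccc1` gives 48500 nM. Among the measured compounds shown here, on these two numbers compound 2 stands highest, so it is the weaker inhibitor of the pair, and the single measured step, a 6.7-fold higher number from compound 1 to compound 2 (0.82 log units; beyond the scatter), shows that swapping the group on the amine nitrogen can move the number by a modest but real amount.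

Compound 3 `NC(=O)C1CCN(CC(=O)N2N=C(c3cc4ccccc4oc3=O)CC2c2ccccc2)CC1` is not yet measured. It differs from compound 2 in one place: 4-carbamoylpiperidin-1-yl in place of cyclohexylamino on a saturated chain carbon bound to a carbonyl carbon. For the measured compounds named here, no measured step replaces the cyclohexylamino group with a ring that itself carries the nitrogen, so the only guidance comes from the step from compound 1 to compound 2, which only says that changes at this place shift the number modestly rather than strongly. The expectation is therefore a step of a 1.9-fold lower number from compound 2 to compound 3 (0.29 log units; within the scatter) that is small and could fall within the scatter in either direction. Compound 3 is expected to give about 25000 nM, within a range from 6000 nM to 100000 nM.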

Compound 3, half-maximal inhibitory concentration: 8310 nM
Estimate against measurement, compound 3: 3.0-fold (0.48 log units) above; the range from low to high includes it.
By their numbers in this assay, from the lowest: compounds 1 and 3 (each within the scatter of the next); then compound 2.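

In this assay, replacing the cyclohexylamino group gives a 5.8-fold lower number from compound 2 to compound 3 (0.77 log units; beyond the scatter), so a six-membered ring at this place, on a saturated chain carbon bound to a carbonyl carbon, does not by itself go with a weak number. The two compounds with the better numbers carry quite different groups, a ring in 4-carbamoylpiperidin-1-yl and an open chain in propylamino, yet the change between them gives a 1.1-fold higher number from compound 1 to compound 3 (0.06 log units; within the scatter), so the two cannot be told apart in this assay. Compound 2 is therefore the weakest of the three, and among these three groups only cyclohexylamino stands apart, whereas the earlier pair could not show whether a ring at this place was enough to weaken the number.

The compounds shown leave open how much of the result belongs to the piperidine ring and how much to the carbamoyl group on it, a question that a plain piperidine, or a piperidine carrying a carboxylic acid in place of the carbamoyl group, would address. Nothing available here explains why the cyclohexylamino group stands apart from the other two.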